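The compounds below may be only part of what the source reports. "The series", "measured", "known", "first", "only" and "open" are said of these compounds alone.

Measured in a functional assay on HL-60 cells (Homo sapiens) for inhibition, read by MTT assay, with a stated time of 72 h; a higher number here means a weaker inhibitor, a lower number a stronger inhibitor:
Compound 1 `CC(=O)c1ccc(N2CCN(C(=O)c3oc(C)nc3-c3ccccc3)CC2)cc1`: "not active" (no number reported)
Compound 2 `Cc1ccc(N2CCN(C(=O)c3oc(C)nc3-c3ccccc3)CC2)cc1`: > 1000 nM (a limit of the assay, not a number)

Compound 2 stands at > 1000 nM in this assay, which is a limit and gives no exact position. Compound 1 gives "not active" (no number reported), so neither compound has a single number, and the data so far amount to the limit of > 1000 nM in this assay, at which 1 of the 2 values shown sits.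

Compound 3 `Cc1nc(-c2ccccc2)c(C(=O)N2CCN(c3ccccc3Cl)CC2)o1` has not yet been measured. It carries 2-chlorophenyl in place of 4-methylphenyl on an amine nitrogen in a ring. Going by the values given here, no step between measured compounds is available as a guide. In this assay, no step beyond the scatter is expected, in either direction. The estimated change is a step that the limit leaves unreadable from compound 2 to compound 3. For compound 3 the expected value is 1800 nM, with an estimated range from 500 nM to 10000 nM.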

Compound 3, half-maximal inhibitory concentration: 124 nM
Estimate against measurement, compound 3: 15-fold (1.16 log units) above; measured number below the stated range.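

In this assay, compound 3 gives the first single number among the compounds shown, so a group on this amine nitrogen in a ring can go with measurable inhibition while the rest of the molecule stays the same. Placing 2-chlorophenyl in place of 4-methylphenyl gives an at least 8.0-fold lower number from compound 2 to compound 3 (0.90 log units; beyond the scatter), a step beyond the usual scatter. Its size can be read only as a minimum because compound 2 stands at a limit: the limit of > 1000 nM in this assay, at which 1 of the 3 values shown sits.

The change swaps the methyl group for a chlorine and moves the substituent on the phenyl ring in one step, so the compounds shown cannot separate these two parts of it. On these data alone, how a methoxy group or an amine in place of the chlorine would read also stays open.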